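The source may report more compounds than this note shows. Statements on the series, on what has been measured and on what is new or still open speak of the compounds shown alone.

Measured compounds in an assay on NIH3T3 cells with Urotensin-2 receptor (Homo sapiens) as the target; a higher number here means a larger maximal response, a lower number a smaller maximal response:
compound 1, `COc1ccc(C(=O)NC(CCN(C)C)c2ccc(Cl)cc2)cc1`, 162%
compound 2, `Cc1cccc(C(=O)NC(CCN(C)C)c2ccc(Cl)cc2)c1C`, 159%
compound 3, `Cc1c(Cl)cccc1C(=O)NC(CCN(C)C)c1ccc(Cl)cc1`, 142%

Compound 3 stands lowest of the three in this assay: the two steps down to it are a number 17 percentage points lower from compound 2 to compound 3 (beyond the scatter) and a number 20 percentage points lower from compound 1 to compound 3 (beyond the scatter), both beyond the scatter, whereas compound 1 and compound 2 sit within the scatter of each other, a number 3 percentage points lower from compound 1 to compound 2 (within the scatter).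

Compound 4, `Cc1ccc(C)c(C(=O)NC(CCN(C)C)c2ccc(Cl)cc2)c1`, has not yet been measured. Its change from compound 3 is 2,5-dimethylphenyl in place of 3-chloro-2-methylphenyl on a carbonyl carbon.

For the measured compounds named here, two measured steps bear on it. The step of a number 17 percentage points lower from compound 2 to compound 3 (beyond the scatter) exchanged a methyl for a chloro on the aromatic ring and lowered the maximal response; compound 4 undoes that exchange and carries two methyl groups again, though as the 2,5-dimethylphenyl rather than the 2,3-dimethylphenyl of compound 2. The step of a number 3 percentage points lower from compound 1 to compound 2 (within the scatter) shows that a dimethylphenyl and the 4-methoxyphenyl give maximal responses within the scatter of each other. Taken together, the maximal response of compound 4 in this assay is expected to return roughly to the level of compound 2, an upward step of a number 15 percentage points higher from compound 3 to compound 4 (beyond the scatter). Compound 4 is therefore estimated at 157%, with a range of 140% to 175%.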

Compound 4, largest response reached (reported as efficacy), in percent of the reference or control that the assay uses: 164%
Compound 4: the middle estimate sits 7 percentage points below what was measured; the measured number falls inside the stated range.
By their numbers in this assay, from the lowest: compound 3; then compounds 2, 1 and 4 (each within the scatter of the next).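

In this assay, the group on the carbonyl carbon keeps its response when the dimethylphenyl pattern changes: a number 5 percentage points higher from compound 2 to compound 4 (within the scatter) and thus 2,5-dimethylphenyl cannot be separated from 2,3-dimethylphenyl, while a number 2 percentage points higher from compound 1 to compound 4 (within the scatter) and thus 4-methoxyphenyl cannot be separated from 2,5-dimethylphenyl either. A second comparison for the chloro-bearing group comes from a number 22 percentage points higher from compound 3 to compound 4 (beyond the scatter) and shows the same direction as the earlier step from the 2,3-dimethylphenyl compound. Among these four compounds, 3-chloro-2-methylphenyl is therefore the only group on the carbonyl carbon that stands apart. No available data explain this separation.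

As far as these compounds go, whether a trifluoromethyl or a nitrile in place of the chloro would also give the lower response remains open. Also open, from the compounds shown here alone, is how an aminophenyl or a carboxyphenyl group would behave on the carbonyl carbon.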